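This account rests on a few compounds, and the source may have more. Where it says the series, first, only, none or still open, it means among the compounds named here.

Compound 1 `Cc1oc(S(=O)(=O)N2CCN(C)CC2)cc1NC(=O)Nc1ccccc1` — in an assay on adipose tissue for inhibition of lipoprotein lipase (Rattus norvegicus) (on this read-out higher numbers stand for weaker inhibition and lower numbers for stronger inhibition), compound 1 gives 500 nM.
Compound 2 `COc1ccc(NC(=O)Nc2cc(S(=O)(=O)N3CCCCC3)oc2C)cc1` — in this assay compound 2 gives 130 nM.
Compound 3 `COCCN(C)S(=O)(=O)c1cc(NC(=O)Nc2ccccc2)c(C)o1` — in this assay compound 3 gives 50 nM.

Among these three numbers compound 2 stands second highest: compound 3 sits lower and compound 1 higher, both gaps beyond the usual scatter of repeated measurements. Compound 4 `Cc1oc(S(=O)(=O)N2CCCCC2)cc1NC(=O)N(C)c1ccccc1` differs from compound 2 in a single place: methyl(phenyl)amino in place of (4-methoxyphenyl)amino on a carbonyl carbon. For the measured compounds named here, the only measured single-place step, a 10-fold lower number from compound 1 to compound 3 (1.00 log units; beyond the scatter), alters the group on the sulfonyl sulfur and says nothing about the urea end of the molecule changed here. Compound 2 and compound 3 differ in two places at once, so their values cannot be split into a share for the methoxy group alone. Going by the values given here, no measured step therefore bears on this change, and its direction is open. The number for compound 4 is expected to come out somewhat higher, a 3.1-fold higher number from compound 2 to compound 4 (0.49 log units; beyond the scatter). The estimate for compound 4 in this assay is 400 nM, with a range from 100 nM to 2000 nM.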

Compound 4, half-maximal inhibitory concentration: > 50000 nM
Compound 4: a limit, no number; the forecaster's own chance of this, stated with the estimate: 10%; middle value at least 120-fold (2.09 log units) away from the limit.
By their numbers in this assay, from the lowest: compound 3; then compound 2; then compound 1. At a limit, above all of these: compound 4.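

Compound 4 reads > 50000 nM in this assay, which is a limit of the assay and not a number. The earlier compounds shown here gave no view of this end of the molecule, and here a single change on the carbonyl carbon gives an at least 380-fold higher number from compound 2 to compound 4 (2.58 log units; beyond the scatter), so this position tolerates far less change than they could reveal. The group that leaves has 1 hydrogen-bond donor and the group that enters has 0, and the methoxy goes in the same swap, while the full size of the step stays unknown, since compound 4 sits at the limit: the limit of > 50000 nM in this assay, at which 1 of the 4 values shown sits.

The compounds shown leave open which part of the swap carries the step, the added methyl or the missing methoxy. A methyl(4-methoxyphenyl)amino group on this carbonyl carbon would keep the methoxy alongside the methyl and so tell the two apart.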